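The compounds below may be only part of what the source reports. "The series", "measured", "known", "first", "only" and "open" are said of these compounds alone.

Values in an ADME assay on the whole organism (strain S2) for cytotoxicity, with Drosophila as the target, read by WST assay; on this read-out lower numbers stand for higher toxicity in this test and higher numbers for lower toxicity in this test:

- Compound 1 `CCCCCCCC(=O)c1c(OC)c(Cl)c(OC)c(Cl)c1OC`: 51400 nM
- Compound 2 `CCCCCC(=O)c1c(O)cc(OC)c(Cl)c1O`: 8700 nM
- Compound 3 `CCCC(=O)c1c(O)c(Cl)c(O)c(Cl)c1O`: > 100000 nM (a limit of the assay, not a number)

Compound 1 gives 51400 nM, the higher of the two actual numbers in this assay. Compound 2 gives 8700 nM, a lower number, and that gap lies beyond the usual scatter. Compound 3 has only a limit, so it cannot be ranked exactly.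

The next compound is compound 4 `CCCCC(=O)c1c(OC)c(Cl)c(OC)c(Cl)c1OC`, which keeps the core of compound 1 and shortens the chain on the carbonyl. The counted change is hydrogen in place of propyl on a saturated chain carbon, four bonds along the chain from a carbonyl carbon.

Among the measured compounds shown here, no measured pair shows this change alone, so the evidence is thin. Compound 3 also has a shorter chain than compound 1. Compound 3 gives > 100000 nM, which is a limit. Compound 2 goes against that hint, since its chain is also shorter than that of compound 1, yet compound 2 gives 8700 nM.

A small rise in the number is expected, probably not clearly beyond the scatter, and the estimated change is a 1.8-fold higher number from compound 1 to compound 4 (0.24 log units; within the scatter). For compound 4 the estimated value is 90000 nM, with an expected range from 35000 nM to 200000 nM.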

Compound 4, half-maximal cytotoxic concentration: 149000 nM
For compound 4 the middle estimate is 1.7-fold (0.22 log units) below the measured one, within the range that was stated.
By their numbers in this assay, from the lowest: compound 2; then compound 1; then compound 4.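

In this assay, hydrogen in place of propyl on a saturated chain carbon, four bonds along the chain from a carbonyl carbon, gives a 2.9-fold higher number from compound 1 to compound 4 (0.46 log units; beyond the scatter). This is the first pair shown in which the core stays the same and only the chain on the carbonyl changes, so the effect of this change can be read on its own rather than inferred from compounds that also differ elsewhere. Since a higher number on this read-out stands for lower toxicity in this test, the shorter chain of compound 4 is the less toxic of this pair, though the step is modest and comes from a single pair on a single core.

As far as these compounds go, a chain longer than that of compound 1, a chain carrying an amine or a carboxylic acid, and the same shortening on a different core all remain open, and one step cannot establish a trend with chain length. Compound 3 remains a limit and not a number, so its place in the order stays open: the limit of > 100000 nM in this assay, at which 1 of the 4 values shown sits.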